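The source may hold more compounds than are shown below. What is called first, only, known or untested is meant among the compounds shown, and "the series" means these compounds.

Measured in an ADME assay on microsomes from liver (Homo sapiens) for metabolic stability; a lower number here means that the compound disappears faster, a higher number that the compound lasts longer:
- compound 1 `COC[C@H](NC(=O)c1cc(C)on1)C(=O)N[C@@H](CSC)C(=O)N[C@@H](CC(C)C)C(=O)[C@@]1(C)CO1`: 0.283 h
- compound 2 `CSC[C@H](NC(=O)c1cc(C)on1)C(=O)N[C@@H](CSC)C(=O)N[C@@H](CC(C)C)C(=O)[C@@]1(C)CO1`: 0.108 h
- compound 3 `CSC[C@H](NC(=O)c1cc(C)on1)C(=O)NCC(=O)N[C@@H](CC(C)C)C(=O)[C@@]1(C)CO1`: 0.527 h

Compound 2 stands lowest of the three, at 0.108 h. Compound 4 `CSC[C@H](NC(=O)c1cnc(C)s1)C(=O)N[C@@H](CSC)C(=O)N[C@@H](CC(C)C)C(=O)[C@@]1(C)CO1` has not yet been measured. Its difference from compound 2 is 2-methyl-1,3-thiazol-5-yl in place of 5-methyl-1,2-oxazol-3-yl on a carbonyl carbon, which places 2-methyl-1,3-thiazol-5-yl in place of 5-methyl-1,2-oxazol-3-yl on a carbonyl carbon.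

Two measured steps start from or end at compound 2: a 2.6-fold lower number from compound 1 to compound 2 (0.42 log units; beyond the scatter) and a 4.9-fold higher number from compound 2 to compound 3 (0.69 log units; beyond the scatter). Both are modest and beyond the scatter, but each is a change elsewhere in the molecule. All three measured compounds carry 5-methyl-1,2-oxazol-3-yl, so neither step shows this exchange directly. They give a rough size for movement in the series and no direction for this change.

No step beyond the scatter is therefore expected, and the estimated step is a 1.0-fold higher number from compound 2 to compound 4 (0.01 log units; within the scatter). For compound 4 the expected half-life is 0.11 h, with an estimated range of 0.05 h to 0.25 h.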

Compound 4, half-life: 0.103 h
The estimate for compound 4 lay 1.1-fold (0.03 log units) above the measured number; the range from low to high includes it.
By their numbers in this assay, from the lowest: compounds 4 and 2 (each within the scatter of the next); then compounds 1 and 3 (each within the scatter of the next).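

For the compounds shown here, the first direct reading of this position in this assay shows no separation between the two rings: with 2-methyl-1,3-thiazol-5-yl in place of 5-methyl-1,2-oxazol-3-yl on the carbonyl carbon, the result is a 1.0-fold lower number from compound 2 to compound 4 (0.02 log units; within the scatter). Going by these compounds alone, the earlier steps at the two chain positions, a 2.6-fold lower number from compound 1 to compound 2 (0.42 log units; beyond the scatter) and a 4.9-fold higher number from compound 2 to compound 3 (0.69 log units; beyond the scatter), both lie beyond the scatter, so in the setting of compound 2 this ring exchange is the only one of the three changes that leaves the half-life within the scatter. Nothing available bears on the reason for this result.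

Going by these compounds, whether the same exchange stays within the scatter on the background of compound 1 or compound 3 remains open. Also open, on these data alone, is how a phenyl ring or a saturated amine such as morpholine would read on this carbonyl carbon.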